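The source may report more compounds than this note shows. Statements on the series, on what has been measured and on what is new or still open speak of the compounds shown alone.

The measured compounds:
Compound 1 `N=C1S/C(=C\c2ccc(OCc3ccccc3)cc2)C(=O)N1c1ccc(F)cc1`: in an ADME assay on RAW264.7 cells (Mus musculus) for cytotoxicity, read by MTT assay, with a stated time of 48 h, tested at 50 uM (a higher number here means more inhibition at the concentration tested (going by the name of the read-out), a lower number less inhibition), compound 1 gives 10.5%.
Compound 2 `N=C1S/C(=C\c2ccc(OCc3ccccc3)cc2)C(=O)N1c1ccccc1[N+](=O)[O-]`: in this assay compound 2 gives 24.4%.

Compound 2 stands highest of the two numbers in this assay; its nearest neighbour is compound 1, and the step of a number 13.9 percentage points higher from compound 1 to compound 2 (beyond the scatter) lies beyond the scatter. Compound 3 `N=C1S/C(=C\c2ccc(OCc3ccccc3)cc2)C(=O)N1c1ccc(Cl)cc1Cl` differs from compound 2 in one place: 2,4-dichlorophenyl in place of 2-nitrophenyl on an amide-type nitrogen in a ring. For the measured compounds named here, no measured step puts a 2,4-dichlorophenyl in place of a 2-nitrophenyl on an amide-type nitrogen in a ring, so there is no direct precedent. Going by the values given here, the only measured step on that nitrogen, a number 13.9 percentage points higher from compound 1 to compound 2 (beyond the scatter), shows that exchanging the group there can move the read-out in this assay by a modest amount. With no closer comparison, a step of that order in either direction remains possible, and as the central case a change no larger than the scatter is expected, a number 6.4 percentage points lower from compound 2 to compound 3 (within the scatter) being the expected step. For compound 3 the estimated value in this assay is 18%, with a range from 5% to 35%.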

Compound 3, a percentage reported as inhibition, at one concentration (the size of the read-out at that concentration, not a potency): 13.8%
Estimate against measurement, compound 3: 4.2 percentage points above; low and high end bracket the measured number.
By their numbers in this assay, from the lowest: compounds 1 and 3 (each within the scatter of the next); then compound 2.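

Exchanging 2-nitrophenyl for 2,4-dichlorophenyl on the amide-type nitrogen in a ring gives a number 10.6 percentage points lower from compound 2 to compound 3 (beyond the scatter) in this assay, so a second exchange at this position now moves the read-out beyond the scatter, and both such steps involve the 2-nitrophenyl group. The other exchange, 2,4-dichlorophenyl in place of 4-fluorophenyl, gives a number 3.3 percentage points higher from compound 1 to compound 3 (within the scatter) and leaves these two chlorine- and fluorine-bearing groups unseparated, so that among the three compounds only compound 2 stands apart from both others. Nothing available bears on what lies behind this difference.

The compounds shown leave open whether the separation of compound 2 belongs to the nitro group itself or to 2-nitrophenyl as a whole, a question that a phenyl ring carrying an amine or a carboxylic acid on this nitrogen would begin to address. They also leave open whether a non-aromatic group at this place, such as a longer alkyl chain, would keep the read-out at a similar level, and how any of these exchanges would behave with a different group in place of the benzyloxy part of the shared core.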